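Swapping a cyclopropyl amide for a cyclohexylmethyl amine

The source may report more compounds than this note shows. Statements on the series, on what has been measured and on what is new or still open speak of the compounds shown alone.

Measured so far:
- compound 1, `O=C(Nc1ccc2nc(NC(=O)C3CCCCC3)sc2c1)c1ccccc1Oc1ccccc1`: 0.1 ug/mL
- compound 2, `O=C(Nc1ccc2nc(NC(=O)C3CC3)sc2c1)c1c(Cl)cccc1Cl`: 0.013 ug/mL

Both compounds share a core carrying two substituted nitrogens, and both were tested in a functional assay on WI-38 VA13 cells (Homo sapiens) for cytotoxicity; on this read-out higher numbers stand for an effect only at larger amounts of compound and lower numbers for an effect already at smaller amounts. Compound 1 gives 0.1 ug/mL in this assay, while compound 2 gives 0.013 ug/mL. Of the two numbers, compound 2 has the lower one, and the gap to compound 1 lies beyond the usual scatter, so on these two results compound 2 is the more potent.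

The next compound, compound 3 `O=C(Nc1ccc2nc(NCC3CCCCC3)sc2c1)c1c(Cl)cccc1Cl`, keeps the dichlorobenzoyl portion of compound 2 and changes only the other nitrogen: cyclohexylmethyl in place of cyclopropylcarbonyl on a nitrogen on an aromatic ring. The carbonyl and its hydrogen-bond acceptor disappear, and a larger saturated ring arrives. Among the measured compounds shown here, no pair of measured compounds shows a change of this kind, so no measured step can guide the expectation directly.

On that basis the expected step of a 7.7-fold higher number from compound 2 to compound 3 (0.89 log units; beyond the scatter) is toward a higher number, somewhat beyond the scatter, though with wide uncertainty. Compound 3 is therefore estimated at 0.1 ug/mL, within a range from 0.02 ug/mL to 0.6 ug/mL.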

Compound 3, half-maximal effective concentration: 4.3 ug/mL
Compound 3: middle estimate off by 43-fold (1.63 log units), on the low side; measured number outside the range, above it.
By their numbers in this assay, from the lowest: compound 2; then compound 1; then compound 3.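

In this assay this nitrogen on an aromatic ring proves highly sensitive to what it carries: replacing cyclopropylcarbonyl with cyclohexylmethyl gives a 330-fold higher number from compound 2 to compound 3 (2.52 log units; beyond the scatter) and makes this a large step, well beyond the scatter. Among the compounds shown here, this is the first measured comparison in which the compounds differ in one place only, so the whole step can be assigned to this change, with the dichlorobenzoyl portion left as it was. No measurement shown explains why the number rises so far, so the result records the size of the change but not its cause.

The step swaps several features at once, since the carbonyl leaves, the three-membered ring gives way to a six-membered ring, and the count of heavy atoms rises, so the compounds shown cannot tell which of these matters most. From the compounds shown here alone, a cyclopropylmethyl group on the same nitrogen would keep the small ring without the carbonyl, while a plain acetyl group would keep the carbonyl without any ring, and where either would fall between these two results remains open.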